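The source may hold more compounds than are shown below. What is called first, only, known or untested is meant among the compounds shown, and "the series" means these compounds.

The series shares one core, seen in compound 1 `O=C(c1c(O)ccc2cc(-c3cccc(O)c3)ccc12)N1CCOCC1`; in an in vitro assay on Sf9 cells for inhibition of 17-beta-hydroxysteroid dehydrogenase type 1 (Homo sapiens), tested at 100 nM (a higher number here means a stronger effect of the compound at the concentration tested, a lower number a weaker effect), compound 1 gives 28%. Compound 2 `O=S(=O)(c1ccccc1)c1c(O)ccc2cc(-c3cccc(O)c3)ccc12` carries a sulfonyl linkage in place of the amide, and in this assay compound 2 gives "not determined" (no result reported). Compound 3 `Cc1nnc(NC(=O)c2c(O)ccc3cc(-c4cccc(O)c4)ccc23)s1` carries an amide to a 5-methyl-1,3,4-thiadiazol-2-yl group, and in this assay compound 3 gives "not determined" (no result reported). Among the measured compounds shown here, compound 3 thus stands without a single number, compound 2 is in the same position, and the only number in the set comes from compound 1.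

Compound 4 `O=C(Nc1ccccc1)c1c(O)ccc2cc(-c3cccc(O)c3)ccc12` is to be measured in this assay. It differs from compound 3 in one place: phenyl in place of 5-methyl-1,3,4-thiadiazol-2-yl on an amide-type nitrogen. For the measured compounds named here, no step between two measured compounds is known, so nothing in the set says how large a change at the amide nitrogen should be. The amide of compound 1 reaches a modest inhibition, and a change of the group on the amide nitrogen is expected to shift the read-out by a moderate amount in either direction, not clearly beyond the scatter. Compound 4 is expected to give about 35% in this assay, with a range from 5% to 65%.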

Compound 4, a percentage reported as inhibition, at one concentration (the size of the read-out at that concentration, not a potency): 40%
Estimate against measurement, compound 4: 5 percentage points below; the range from low to high includes it.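

Among the compounds shown here, the first readable step comes at the carbonyl carbon: in this assay, anilino in place of morpholin-4-yl gives a number 12 percentage points higher from compound 1 to compound 4 (beyond the scatter) and so shows that the read-out responds to the group held at this place. With compound 4 at 40%, the inhibition remains partial at the single concentration tested, so the step speaks to the size of the read-out and not to potency, and steps involving compound 2 or compound 3 cannot be read. Nothing available bears on the origin of this step.

Still open, as far as these compounds go, is whether the higher read-out belongs to the aromatic ring of anilino or to the amide hydrogen that comes with it; a methyl(phenyl)amino group or a benzylamino group on the same carbonyl carbon would separate these two readings. Also open, from the compounds shown here alone, is how far the read-out of compound 4 moves when the phenyl ring carries a methoxy group or a carboxylic acid, or when a pyridine ring takes its place.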